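The compounds below may be only part of what the source reports. "The series", "measured", "known", "first", "only" and "open" are said of these compounds alone.

Working notes on the series. Two compounds sharing the core carrying the cyclohexane carboxylic acid ether have been measured in an assay on isolated protein for inhibition of Long-chain-fatty-acid--CoA ligase 1 (Mus musculus), read by mass spectrometry, with a stated time of 90 min, in the presence of a further agent that is not named here; a lower number here means a stronger inhibitor, a higher number a weaker inhibitor. Compound 1 `Cc1cccc(Cc2cc3cc(O[C@H]4CC[C@@H](C(=O)O)CC4)ccc3n2C)c1` gives 400 nM in this assay. Among the measured compounds shown here, compound 2 `Cc1ccc(Cc2nc3cc(O[C@H]4CC[C@@H](C(=O)O)CC4)ccc3n2C)cc1` gives 80 nM in this assay, the lower of the two numbers; compound 1, its only neighbour, sits at the higher number, and that gap lies beyond the usual scatter. The two compounds differ in more than one place, so the pair isolates no single change.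

Compound 3 `Cn1c(Cc2cccnc2)nc2cc(O[C@H]3CC[C@@H](C(=O)O)CC3)ccc21` has not yet been measured in this assay. Against compound 2 the change is pyridin-3-yl in place of 4-methylphenyl on a saturated chain carbon bound to an aromatic carbon. For the measured compounds named here, no step between measured compounds covers this change, so the series gives no guide to its size or direction. The expected step is a small one toward a higher number, close to the edge of the scatter: a 2.0-fold higher number from compound 2 to compound 3 (0.30 log units; within the scatter) is the step this estimate means. For compound 3 the estimate in this assay is 160 nM, expected to fall between 50 nM and 600 nM.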

Compound 3, half-maximal inhibitory concentration: > 200000 nM
Compound 3 was reported as a limit; the forecaster's own chance of this, stated with the estimate: 5%; middle value at least 1200-fold (3.09 log units) away from the limit.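

Compound 3 stands in this assay only as a limit of the assay and not as a number: the limit of > 200000 nM in this assay, at which 1 of the 3 values shown sits. Pyridin-3-yl in place of 4-methylphenyl on a saturated chain carbon bound to an aromatic carbon gives an at least 2500-fold higher number from compound 2 to compound 3 (3.39 log units; beyond the scatter), the first step in the series that isolates a single place, and it is a large one. The earlier pair differed in more than one place and could not show this; the new step shows that, on this core, the choice of six-membered aromatic ring at this place can decide between a compound that reads in the nanomolar range and one that reaches the limit.

Still open, going by these compounds, is whether the step rests on the missing methyl or on the ring nitrogen, since this change carries both at once; an unsubstituted phenyl or a methyl-bearing pyridine ring would separate the two. Also open, on these data alone, is how a longer chain carrying the ring, or an amine on the ring, would read in this assay.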